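Benzyl in place of the dienyl chain on the imidazole nitrogen

This account rests on a few compounds, and the source may have more. Where it says the series, first, only, none or still open, it means among the compounds named here.

Compound 1 `CC(C)CCn1cnc2c(Nc3cccc(O)c3)nc(N[C@H]3CC[C@H](N)CC3)nc21`, compound 2 `CCCCn1cnc2c(Nc3cccc(Cl)c3)nc(N[C@H]3CC[C@H](N)CC3)nc21` and compound 3 `CC(C)=CCC/C(C)=C/Cn1cnc2c(Nc3cccc(Cl)c3)nc(N[C@H]3CC[C@H](N)CC3)nc21` share one core and differ at the chain on a saturated carbon bound to an aromatic nitrogen and at the aniline substituent. In a functional assay on BT-474 cells (Homo sapiens) for inhibition, read by fluorescence, with a stated time of 72 h (a lower number here means a stronger inhibitor of growth, a higher number a weaker inhibitor of growth), compound 1 gives 14700 nM, compound 2 gives 5100 nM and compound 3 gives 4300 nM. Compound 3 and compound 2 lie within the scatter of each other, as the step of a 1.2-fold lower number from compound 2 to compound 3 (0.07 log units; within the scatter) shows, while compound 1 sits beyond the scatter above compound 3.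

Compound 4 `N[C@H]1CC[C@H](Nc2nc(Nc3cccc(Cl)c3)c3ncn(Cc4ccccc4)c3n2)CC1` is unmeasured; relative to compound 3 the change is phenyl in place of 2,6-dimethylhepta-1,5-dien-1-yl on a saturated chain carbon bound to an aromatic nitrogen. Within the data shown here, the only step that bears on this place is a 1.2-fold lower number from compound 2 to compound 3 (0.07 log units; within the scatter), where a much longer unsaturated chain replaced a short one without leaving the scatter. Nothing shown separates chain from ring at this position, so no step beyond the scatter is expected in this assay, in either direction. For compound 4 the expected step is a 1.0-fold higher number from compound 3 to compound 4 (0.02 log units; within the scatter), and the estimate for compound 4 is 4500 nM, within 1500 nM to 13000 nM.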

Compound 4, concentration for 50% growth inhibition: 10200 nM
For compound 4 the middle estimate is 2.3-fold (0.36 log units) below the measured one; measured number inside the range.
By their numbers in this assay, from the lowest: compounds 3, 2, 4 and 1 (each within the scatter of the next, the first and the last beyond it).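

In this assay, among these compounds, the place on a saturated chain carbon bound to an aromatic nitrogen now shows a response: a 2.4-fold higher number from compound 3 to compound 4 (0.38 log units; beyond the scatter) is the only step here beyond the scatter, with 3,7-dimethylocta-2,6-dien-1-yl replaced by benzyl. Against the short chain of compound 2, the same benzyl stays within the scatter (a 2.0-fold higher number from compound 2 to compound 4 (0.30 log units; within the scatter)), so the separation holds only against the long dienyl chain, and compound 2 lies within the scatter of both neighbours. No measurement at hand accounts for the gap between chain and ring at this place.

The compounds shown change ring and chain length together, so the two cannot be told apart. Phenethyl or cyclohexylmethyl at this place, or a longer saturated chain ending in an amine, would address that question.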